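Amino for chloro beside iodo: compound 3

A few compounds are considered here, and "the series" means these few. Any claim that something is new, unique, unknown or untested is made for them only; others in the source may bear on it.

The set rests on one shared core with two substituents on the six-membered aromatic ring. Compound 1 `CC(=O)OC(C)n1cnc2c(Cl)nc(N)nc21` carries amino and chloro, compound 2 `CC(=O)OC(C)n1cnc2c(Cl)nc(I)nc21` carries iodo and chloro. In a functional assay (Homo sapiens) for inhibition (on this read-out lower numbers stand for stronger inhibition and higher numbers for weaker inhibition), compound 1 gives > 500000 nM, which is a limit of the assay and not a number (the limit of > 500000 nM in this assay, at which 1 of the 2 values shown sits). In this assay, for the measured compounds named here, compound 2 gives 14500 nM, the only number in the set. Going by the values given here, the only measured step, an at least 34-fold lower number from compound 1 to compound 2 (1.53 log units; beyond the scatter), concerns the site that carries iodo in compound 2.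

Compound 3 `CC(=O)OC(C)n1cnc2c(N)nc(I)nc21` is not yet measured. It differs from compound 2 by amino in place of chloro on an aromatic carbon. No measured step touches this site, so nothing directly bears on the change; the single step shown changes the other position. Among the compounds with values here, the one measured compound that carries an amino group, compound 1, stands at the limit. On that thin basis a weaker number is expected for compound 3, with a 2.8-fold higher number from compound 2 to compound 3 (0.44 log units; beyond the scatter). Compound 3 is estimated at 40000 nM, in a range from 8000 nM to 250000 nM.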

Compound 3, half-maximal inhibitory concentration: > 500000 nM
Compound 3: no number, only a limit (the forecaster's own chance of this, stated with the estimate: 25%); middle value at least 12-fold (1.09 log units) away from the limit.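

In this assay, for the compounds shown here, amino in place of chloro gives an at least 34-fold higher number from compound 2 to compound 3 (1.53 log units; beyond the scatter), the first measured step at this site, which lies meta to the iodo group and opposite the ring nitrogen. Compound 3 gives > 500000 nM, which is a limit of the assay and not a number. Iodo alone therefore does not carry a measurable value in this small set, since with iodo held constant the change from chloro to amino also ends at the limit, and the two single changes around compound 2 now both lead there, leaving compound 2 as the only compound with a number: the limit of > 500000 nM in this assay, at which 2 of the 3 values shown sit.

The compounds shown leave open whether the loss belongs to amino in particular or to any replacement of chloro at this site, a question that bromo, methoxy or methylamino here could help to separate. They also leave open how far compound 3 lies beyond the limit, and whether any group at this site would give a lower number than chloro does in compound 2.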